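A Fluoro Group Replaces Trifluoromethyl on the Shared Core

A few compounds are considered here, and "the series" means these few. Any claim that something is new, unique, unknown or untested is made for them only; others in the source may bear on it.

Of the compounds shown here, three sharing one core have been measured in a functional assay on the whole organism with Mus musculus as the target, with a stated time of 1 h, at a dose of 100 mg/kg by the intraperitoneal route; a lower number here means less inhibition, a higher number more inhibition at the dose given (going by the name of the read-out). Compound 1 `Cc1ccc(COc2nc3ccccc3s2)cc1` gives 1.95%, compound 2 `Fc1ccccc1COc1nc2ccccc2s1` gives 74.6%, and compound 3 `FC(F)(F)c1ccc(COc2nc3ccccc3s2)cc1` gives 12.2%. Compound 3 thus stands second highest of the three: its nearest neighbour is compound 1, whose number is lower beyond the scatter, while compound 2 lies far above it, also beyond the scatter. For the measured compounds named here, the only measured step that touches compound 3 is a number 10.3 percentage points higher from compound 1 to compound 3 (beyond the scatter), a modest rise from a methyl to a trifluoromethyl group.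

Compound 4 `Fc1ccc(COc2nc3ccccc3s2)cc1` is the next to be tested. It differs from compound 3 by fluoro in place of trifluoromethyl on an aromatic carbon. Going by the values given here, no measured step describes this exchange directly. Compound 2 carries a fluoro group on the same ring, though on another carbon, and its value is high, whereas compound 1 with its methyl group is near zero. The estimate for compound 4 therefore stays wide, and this assay is expected to show a step of a number 12.8 percentage points higher from compound 3 to compound 4 (beyond the scatter) toward a value of 25%, between 3% and 60%.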

Compound 4, a percentage reported as inhibition, in the whole organism at one dose (the size of the read-out at that dose, not a potency): 90.7%
For compound 4 the middle estimate is 65.7 percentage points below the measured one, outside the stated range (above it).
By their numbers in this assay, from the lowest: compound 1; then compound 3; then compound 2; then compound 4.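

On the aromatic carbon para to a large group, the choice of substituent matters far more than the step between the two carbon-bearing groups suggested: in this assay fluoro in place of trifluoromethyl gives a number 78.5 percentage points higher from compound 3 to compound 4 (beyond the scatter), and fluoro in place of methyl gives a number 88.8 percentage points higher from compound 1 to compound 4 (beyond the scatter). Both steps far exceed a number 10.3 percentage points higher from compound 1 to compound 3 (beyond the scatter), so among these three compounds methyl and trifluoromethyl stay low while fluoro alone reaches a high number. Nothing available explains why fluoro behaves so differently here.

As far as these compounds go, whether chloro, methoxy, an amine or a carboxylic acid at this place would side with fluoro or with the two low compounds remains open. The compounds shown also leave open whether the high number for compound 4 would hold at other doses or times.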